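The source may hold more compounds than are shown below. What is called first, only, known or untested is meant among the compounds shown, and "the series" means these compounds.

Compound 1 `O=Cc1cn(Cc2ccc(Cl)cc2)c2cc(Br)ccc12`: 90 nM
Compound 2 `OCc1cn(Cc2cccc(F)c2)c2ccccc12`: 40 nM

These two compounds were tested in a functional assay on NCI-H460 cells (Homo sapiens) for cytotoxicity, read by sulforhodamine B assay, with a stated time of 3 days; a higher number here means a weaker inhibitor, a lower number a stronger inhibitor. Compound 2, at 40 nM, holds the lower of the two numbers, and the gap to compound 1 at 90 nM lies beyond the scatter. The next compound to be measured in this assay is compound 3 `OCc1cn(Cc2cccc(Br)c2)c2ccccc12`, which departs from compound 2 at a single place: bromo in place of fluoro on an aromatic carbon. In words, it carries bromo in place of fluoro on an aromatic carbon, and this carbon belongs to a six-membered aromatic ring of carbon only, meta to a large group.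

Within the data shown here, no measured pair shows this change, since compound 1 differs from compound 2 in more than one place. The expectation therefore rests on little more than the small size of the change and on the two values at hand. No step beyond the scatter is expected in either direction, and the estimated 1.1-fold higher number from compound 2 to compound 3 (0.05 log units; within the scatter) stays within it. For compound 3 the estimated value is 45 nM, with an expected range from 15 nM to 130 nM.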

Compound 3, half-maximal inhibitory concentration: 28 nM
Estimate against measurement, compound 3: 1.6-fold (0.21 log units) above, and the stated range covers the measured number.
By their numbers in this assay, from the lowest: compounds 3 and 2 (each within the scatter of the next); then compound 1.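

Among these compounds, compound 3 supplies the first comparison between compounds that differ in one place, and so gives the first direct reading of a change on this aromatic carbon, which belongs to a six-membered aromatic ring of carbon only and stands meta to a large group. In this assay, bromo in place of fluoro gives a 1.4-fold lower number from compound 2 to compound 3 (0.15 log units; within the scatter), so these two halogens cannot be told apart at this position, and the heavier atom brings no loss that can be distinguished from the ordinary spread of repeat measurements. This holds for this one exchange alone, and nothing at hand bears on why the two compounds read alike.

As far as these compounds go, it remains open whether a nitrile, a methoxy group or an amine on this same carbon would also leave the number within the scatter of compound 2 and compound 3, since the two halogens say nothing about groups of other kinds. Also open, from the compounds shown here alone, is what a carboxylic acid or an amine in place of the hydroxymethyl group shared by these two compounds would do, and compound 1 cannot answer this, as it differs from both in more than one place.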